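From cyclopropyl to phenyl on a carbonyl carbon

The compounds below may be only part of what the source reports. "The series", "measured", "known", "first", "only" and "open" are said of these compounds alone.

Values in an ADME assay on HEK293 cells (Homo sapiens) for cytotoxicity (a lower number here means a stronger inhibitor, a higher number a weaker inhibitor), each a limit and not a number:
Compound 1 `CCC(=O)N1C[C@H](NC(=O)c2ccc(-n3ccccc3=O)cc2)[C@H](NC(=O)c2ccc(Cl)s2)C1`: > 100000 nM
Compound 2 `CC(C)(C)C(=O)N1C[C@H](NC(=O)c2ccc(-n3ccccc3=O)cc2)[C@H](NC(=O)c2ccc(Cl)s2)C1`: > 100000 nM
Compound 3 `O=C(N[C@H]1CN(C(=O)C2CC2)C[C@H]1NC(=O)c1ccc(Cl)s1)c1ccc(-n2ccccc2=O)cc1`: > 100000 nM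

Compound 3 shares (the limit of > 100000 nM in this assay, at which 3 of the 3 values shown sit). Compound 4 `O=C(N[C@H]1CN(C(=O)c2ccccc2)C[C@H]1NC(=O)c1ccc(Cl)s1)c1ccc(-n2ccccc2=O)cc1` differs from it as follows: phenyl in place of cyclopropyl on a carbonyl carbon. In words, this is phenyl in place of cyclopropyl on a carbonyl carbon. The relevant evidence comes from changes on that same carbonyl carbon: a step that the two limits leave unreadable from compound 1 to compound 2, a step that the two limits leave unreadable from compound 1 to compound 3 and a step that the two limits leave unreadable from compound 2 to compound 3. On these data alone, none of these gives a size, and phenyl is untested there, so the expectation is uncertain. No step beyond the scatter is expected in this assay, and another limit is likely. The estimated result is a number no higher from compound 3 to compound 4 (the limit leaves the size open). For compound 4 the expected value is 100000 nM, with an estimated range of 30000 nM to 100000 nM.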

Compound 4, half-maximal inhibitory concentration: > 100000 nM
Compound 4 gave a limit, no number; the forecaster's own chance of this, stated with the estimate: 80%; the middle value sits exactly at the limit.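

In this assay compound 4 gives > 100000 nM, a limit and not a number, so its steps from compound 1, compound 2 and compound 3 cannot be read. The compounds shown leave open whether ethyl, tert-butyl, cyclopropyl or phenyl on the carbonyl carbon makes any difference in this assay: the limit of > 100000 nM in this assay, at which 4 of the 4 values shown sit.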